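Swapping the pyridyl arm for a tolyl arm

A few compounds are considered here, and "the series" means these few. Any claim that something is new, unique, unknown or untested is made for them only; others in the source may bear on it.

Of the compounds shown here, two have been tested for inhibition of human topoisomerase 1. Compound 1 `Clc1ccc(-c2cc(-c3cccs3)nc(-c3ccccc3Cl)c2)o1` gives 41.3% in an assay on isolated protein for inhibition of DNA topoisomerase 1 (Homo sapiens), tested at 100 uM (on this read-out higher numbers stand for a stronger effect at the one concentration tested and lower numbers for a weaker effect), and compound 2 `Clc1ccc(-c2cc(-c3cccnc3)nc(-c3cccs3)c2)o1` gives 25.8% in this assay. Compound 2 therefore stands lowest of the two numbers recorded so far, its nearest neighbour being compound 1 with the higher value. Among the compounds with values here, the one step connecting them, a number 15.5 percentage points lower from compound 1 to compound 2 (beyond the scatter), shows that replacing 2-chlorophenyl by pyridin-3-yl cost a modest but real amount of inhibition.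

Compound 3 `Cc1ccc(-c2cc(-c3ccc(Cl)o3)cc(-c3cccs3)n2)cc1` has not yet been measured. It differs from compound 2 as follows: 4-methylphenyl in place of pyridin-3-yl on an aromatic carbon. Within the data shown here, this change is, in part, the reverse of the single step already seen, since a six-membered carbon-only ring again replaces the pyridin-3-yl group, though the entering ring is 4-methylphenyl rather than 2-chlorophenyl. On that basis a modest rise is expected, of about a number 10.2 percentage points higher from compound 2 to compound 3 (beyond the scatter), with wide uncertainty because only a number 15.5 percentage points lower from compound 1 to compound 2 (beyond the scatter) informs it. Compound 3 is estimated to give 36% in this assay, within a range of 18% to 55%.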

Compound 3, a percentage reported as inhibition, at one concentration (the size of the read-out at that concentration, not a potency): 41.8%
Estimate against measurement, compound 3: 5.8 percentage points below; the measured number falls inside the stated range.
By their numbers in this assay, from the lowest: compound 2; then compounds 1 and 3 (each within the scatter of the next).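

In this assay, putting 4-methylphenyl in place of pyridin-3-yl on the aromatic carbon next to the ring nitrogen gives a number 16 percentage points higher from compound 2 to compound 3 (beyond the scatter), so the gap between pyridin-3-yl and a carbon-only ring at this position is now seen with a second such ring and is not peculiar to 2-chlorophenyl. The direct exchange of the two carbon-only rings gives a number 0.5 percentage points higher from compound 1 to compound 3 (within the scatter), so at this position the read-out does not separate 2-chlorophenyl from 4-methylphenyl, even though one carries a chlorine and the other a methyl. Across these three compounds, compound 2 with its pyridin-3-yl group is the only one set apart beyond the scatter, and no compound shown goes against this.

No measurement at hand accounts for the difference between pyridin-3-yl and the two carbon-only rings. On these data alone, it remains open whether a phenyl ring bearing an amine or a carboxylic acid, or a longer alkyl chain in place of the ring, would stay with compound 1 and compound 3 or fall towards compound 2, and whether the same gap would appear with the thiophen-2-yl or 5-chlorofuran-2-yl group exchanged.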